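Sulfonyl aryl swap in the benzylamide series: compound 3 to compound 4

The compounds below may be only part of what the source reports. "The series", "measured", "known", "first", "only" and "open" are said of these compounds alone.

Compound 3 `O=C(NCc1ccc(CNS(=O)(=O)c2ccc(F)cc2)cc1)c1cccnc1` gives the lowest of the three numbers in an assay on MDA-MB-231 cells for displacement of a labelled ligand from C-X-C chemokine receptor type 4 (Homo sapiens), read by fluorescence and microscopy, with stated times of 10 min and 30 min (on this read-out higher numbers stand for an effect only at larger amounts of compound and lower numbers for an effect already at smaller amounts), at 100 nM; compound 1 `Cc1cccc(S(=O)(=O)NCc2ccc(CNC(=O)c3ccccc3C)cc2)c1` gives 1000 nM and compound 2 `O=C(NCc1ccc(CNS(=O)(=O)c2cccc(F)c2)cc1)c1cccnc1` gives 1000 nM. Among the compounds with values here, the only single-place step so far is a 10-fold lower number from compound 2 to compound 3 (1.00 log units; beyond the scatter). Compound 4 `Cc1cccc(S(=O)(=O)NCc2ccc(CNC(=O)c3cccnc3)cc2)c1` differs from compound 3 by 3-methylphenyl in place of 4-fluorophenyl on a sulfonyl sulfur. Compound 1 also carries 3-methylphenyl on the sulfonyl sulfur, but it differs from compound 3 in two places, so only its value is informative. Within the data shown here, the one measured step shows the 3-substituted ring giving the higher number, so a return to a 3-substituted ring in compound 4 is expected to move the number up, estimated as a 5.0-fold higher number from compound 3 to compound 4 (0.70 log units; beyond the scatter). For compound 4 the expected value is 500 nM, within 150 nM to 2000 nM.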

Compound 4, effective concentration (reported as EC, without a stated level of effect): 10 nM
Beside the measured number, compound 4's estimate is 50-fold (1.70 log units) above it; measured number below the stated range.
By their numbers in this assay, from the lowest: compound 4; then compound 3; then compounds 1 and 2 (each within the scatter of the next).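

In this assay the sulfonyl position does not simply favour 4-fluorophenyl: 3-methylphenyl gives a 10-fold lower number from compound 3 to compound 4 (1.00 log units; beyond the scatter) and methyl in place of fluoro on the aromatic carbon gives a 100-fold lower number from compound 2 to compound 4 (2.00 log units; beyond the scatter) at the same time. With 3-methylphenyl held on the sulfonyl sulfur, pyridin-3-yl in place of 2-methylphenyl on the carbonyl carbon gives a 100-fold lower number from compound 1 to compound 4 (2.00 log units; beyond the scatter) as well, so the amide side also moves the number. Nothing available here explains these steps.

As far as these compounds go, whether ethyl or methoxy can replace the methyl remains open. So does the effect of an amine or a carboxylic acid on the sulfonyl aromatic ring.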